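Piperazine nitrogen substituent variation with no binding seen

The source may report more compounds than this note shows. Statements on the series, on what has been measured and on what is new or still open speak of the compounds shown alone.

Three compounds share one core and differ only in the group on an amine nitrogen in a ring. Compound 1 `CC(C)N1CCN(Cc2csc(N)c2C(=O)c2ccc(Cl)cc2)CC1` carries isopropyl there, compound 2 `Nc1scc(CN2CCN(c3cccc(C(F)(F)F)c3)CC2)c1C(=O)c1ccc(Cl)cc1` carries 3-(trifluoromethyl)phenyl, and compound 3 `Nc1scc(CN2CCN(c3ccc(F)c(F)c3)CC2)c1C(=O)c1ccc(Cl)cc1` carries 3,4-difluorophenyl. In an assay on CHO cells for displacement of a labelled ligand from adenosine receptor A1 (Homo sapiens), read by scintillation counting, with a stated time of 120 min, tested at 10 uM (on this read-out higher numbers stand for more inhibition at the one concentration tested (going by the name of the read-out) and lower numbers for less inhibition), compound 1 gives 0%, compound 2 gives 0% and compound 3 gives 0%. Compound 2 is level with both others; the steps are no change at the digits printed from compound 1 to compound 2 (within the scatter), no change at the digits printed from compound 1 to compound 3 (within the scatter) and no change at the digits printed from compound 2 to compound 3 (within the scatter), none beyond the scatter.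

Compound 4 `Nc1scc(CN2CCN(c3cc(F)ccc3F)CC2)c1C(=O)c1ccc(Cl)cc1` is the next variation at the same place: 2,5-difluorophenyl in place of 3-(trifluoromethyl)phenyl on an amine nitrogen in a ring. The step that bears most directly on it is the move from one aryl group to a difluorophenyl group, no change at the digits printed from compound 2 to compound 3 (within the scatter), and the two steps from isopropyl, no change at the digits printed from compound 1 to compound 2 (within the scatter) and no change at the digits printed from compound 1 to compound 3 (within the scatter), point the same way. No change beyond the scatter is therefore expected in this assay, and the step from compound 2 is estimated as a number 2 percentage points higher from compound 2 to compound 4 (within the scatter). Compound 4 is expected to give 2%, within -8% to 12%.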

Compound 4, a percentage reported as inhibition, at one concentration (the size of the read-out at that concentration, not a potency): 1%
For compound 4 the middle estimate is 1 percentage points above the measured one; the range from low to high includes it.
By their numbers in this assay, from the lowest: compounds 1, 2, 3 and 4 (each within the scatter of the next).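

In this assay, a second placement of the two fluorines on the phenyl group at this amine nitrogen stays within the scatter, a number 1 percentage points higher from compound 3 to compound 4 (within the scatter). Going by these compounds alone, the same holds for the exchange of the trifluoromethyl-bearing aryl group, a number 1 percentage points higher from compound 2 to compound 4 (within the scatter), and of isopropyl, a number 1 percentage points higher from compound 1 to compound 4 (within the scatter), so the flat read-out now extends to a change in fluorine placement on the aryl group, which the earlier compounds did not cover. Nothing measured here bears on why the read-out stays flat.

With all four compounds lying within the scatter of one another, these data do not show whether any group at this nitrogen can produce measurable displacement. A benzyl group, or a longer chain ending in a carboxylic acid or an amine, would test this position with a different kind of substituent.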